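The source may hold more compounds than are shown below. What is called first, only, known or untested is meant among the compounds shown, and "the series" means these compounds.

Compound 1 `OC[C@@H]1C[C@H](CO)[C@@H]2C(c3ccccc3Cl)=NO[C@H]12` in a functional assay on A549 cells (Homo sapiens) for cytotoxicity, read by MTT assay, with a stated time of 48 h (on this read-out higher numbers stand for weaker inhibition and lower numbers for stronger inhibition), gives > 50 ug/mL, which is a limit of the assay rather than a number. Compound 2 `OC[C@@H]1C[C@H](CO)[C@@H]2C(c3ccc(Cl)cc3)=NO[C@H]12` gives > 50 ug/mL, also a limit. Compound 3 `OC[C@@H]1C[C@H](CO)[C@@H]2C(c3ccc4ccccc4c3)=NO[C@H]12` gives > 50 ug/mL, again a limit.

Compound 2 thus stands where every measured compound stands, at the limit of > 50 ug/mL in this assay, at which 3 of the 3 values shown sit, with no number of its own. Compound 4 `Cc1ccc(C2=NO[C@@H]3[C@H](CO)C[C@H](CO)[C@H]23)cc1` differs from compound 2 in one place: methyl in place of chloro on an aromatic carbon. For the measured compounds named here, no step between measured compounds is available to guide the expectation, and all three measured values rest at the same limit. The change is therefore expected to give no step beyond the scatter in this assay, a step that the limit leaves unreadable from compound 2 to compound 4. Compound 4 is expected to sit near or past the same limit, estimated at 60 ug/mL, with a range from 30 ug/mL to 120 ug/mL.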

Compound 4, half-maximal inhibitory concentration: > 50 ug/mL
Compound 4 was reported as a limit (the forecaster's own chance of this, stated with the estimate: 80%); the middle value does not contradict the limit.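

Compound 2 and compound 4 both rest at a limit rather than a number, and no step can be read between them: the limit of > 50 ug/mL in this assay, at which 4 of the 4 values shown sit. The compounds shown leave open whether methyl in place of chloro changes cytotoxicity at all.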